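Acid ceramidase series: fluoro in place of the biaryl

The source may hold more compounds than are shown below. What is called first, only, known or untested is meant among the compounds shown, and "the series" means these compounds.

Measured compounds:
compound 1 `COc1ccc(-c2ccc3c(c2)oc(=O)n3C(=O)NCCCCc2ccccc2)cc1`: 67 nM
compound 2 `O=C(NCCOCc1ccccc1)n1c(=O)oc2ccccc21`: 649 nM
compound 3 `Cc1cccc2oc(=O)n(C(=O)NCCCCc3ccccc3)c12`: no result reported

In an assay on HEK293 cells for inhibition of acid ceramidase (Homo sapiens), with a stated time of 10 min (on this read-out higher numbers stand for weaker inhibition and lower numbers for stronger inhibition), compound 1 gives 67 nM, the lowest of the two numbers in hand. Compound 2 gives 649 nM, a higher number beyond the scatter, but it differs from compound 1 in more than one place, so the gap cannot be tied to any single change. Compound 3 has no reported value.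

Compound 4 `O=C(NCCCCc1ccccc1)n1c(=O)oc2cc(F)ccc21` differs from compound 1 by fluoro in place of 4-methoxyphenyl on an aromatic carbon. For the measured compounds named here, no measured pair isolates this change, so the step is uncertain; removing the 4-methoxyphenyl group is expected to weaken inhibition. The step from compound 1 to compound 4 is estimated as a 3.3-fold higher number from compound 1 to compound 4 (0.52 log units; beyond the scatter), a loss beyond the scatter. Compound 4 is expected at 220 nM, within 60 nM to 800 nM.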

Compound 4, half-maximal inhibitory concentration: 31 nM
Beside the measured number, compound 4's estimate is 7.1-fold (0.85 log units) above it; the measured number lies below the stated range.
By their numbers in this assay, from the lowest: compound 4; then compound 1; then compound 2.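

In this assay the 4-methoxyphenyl group on this aromatic carbon proves dispensable: fluoro in its place gives a modest gain beyond the scatter (a 2.2-fold lower number from compound 1 to compound 4 (0.33 log units; beyond the scatter)). The six-membered aromatic ring that leaves is therefore not needed for inhibition at this position.

On these data alone, whether the gain belongs to fluoro itself or to the loss of the larger group stays open, and hydrogen, chloro or methoxy on this carbon would separate the two. Also open, as far as these compounds go, is whether the step holds with the side chain of compound 2. No evidence in hand accounts for the result.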